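This account rests on a few compounds, and the source may have more. Where it says the series, first, only, none or still open, it means among the compounds named here.

In a functional assay on the whole organism for antagonist activity, with Mus musculus as the target (a higher number here means that more compound is needed for the effect, a lower number that less compound is needed), compound 3 `Cn1c(-c2ccccc2)nnc1S(C)(=O)=O` gives > 200 mg/kg, a limit and not a number. Compound 1 `Cn1c(-c2cccc(F)c2)nnc1S(C)(=O)=O` gives > 200 mg/kg, also a limit. Compound 2 `CSc1nnc(-c2ccc(F)cc2)n1C` gives > 200 mg/kg, again a limit. The evidence so far amounts to the limit of > 200 mg/kg in this assay, at which 3 of the 3 values shown sit. Compound 4 `CC[S+]([O-])c1nnc(-c2ccccc2)n1C` departs from compound 3 by a group of 4 heavy atoms (2 carbon, 1 oxygen, 1 sulfur; no ring) in place of a group of 4 heavy atoms (1 carbon, 2 oxygen, 1 sulfur; no ring), on an aromatic carbon. For the measured compounds named here, no measured step covers this change at that place on the shared core. Going by the values given here, the only measured step, a step that the two limits leave unreadable from compound 1 to compound 3, concerns another place and gives neither size nor direction. The expected step is therefore only a rough estimate, a number no higher from compound 3 to compound 4 (the limit leaves the size open), set near that limit. Compound 4 is expected at 200 mg/kg, with an estimated range of 80 mg/kg to 400 mg/kg.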

Compound 4, dose for half-maximal effect: > 200 mg/kg
Compound 4 was reported as a limit; the forecaster's own chance of this, stated with the estimate: 70%; the middle value lies on the limit itself.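

For the compounds shown here, compound 3 and compound 4 are both reported as limits, and no step between them can be read. The compounds shown leave open whether any change on the shared core gives a measurable dose in this assay: the limit of > 200 mg/kg in this assay, at which 4 of the 4 values shown sit.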